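The source may hold more compounds than are shown below. What is called first, only, known or untested is meant among the compounds shown, and "the series" means these compounds.

Measured compounds:
compound 1 `CCCc1ccc(NC2=CC(=O)c3nc4n(c3C2=O)[C@H]2OC[C@@H](O)[C@H]2OC4)cc1`: 4990 nM
compound 2 `O=C1C(NC2CCCC2)=CC(=O)c2c1nc1n2[C@H]2OC[C@@H](O)[C@H]2OC1`: > 16000 nM (a limit)
compound 3 `COc1ccc(NC2=CC(=O)c3c(nc4n3[C@H]3OC[C@@H](O)[C@H]3OC4)C2=O)cc1`: > 8000 nM (a limit)

Among the measured compounds shown here, in a functional assay on HeLa cells (Homo sapiens) for inhibition, read by sulforhodamine B assay (a lower number here means a stronger inhibitor, a higher number a weaker inhibitor), compound 1 gives 4990 nM, the only actual number. Compound 2 stands at > 16000 nM, which is a limit of the assay. Compound 3 stands at > 8000 nM, also a limit. Compound 1 can therefore be placed on the scale, but it cannot be properly ranked against the other two.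

Compound 4 `COc1ccccc1NC1=CC(=O)c2nc3n(c2C1=O)[C@H]1OC[C@@H](O)[C@H]1OC3` has 2-methoxyphenyl in place of 4-propylphenyl on an amine nitrogen. For the measured compounds named here, the one measured step is a step that the two limits leave unreadable from compound 2 to compound 3, and it gives no size to carry over. The closest guide is therefore compound 3, which carries 4-methoxyphenyl. Weaker inhibition is expected for compound 4 since compound 3 stands at > 8000 nM, a limit. The estimated change is a 1.8-fold higher number from compound 1 to compound 4 (0.26 log units; within the scatter), a modest step in this assay towards weaker inhibition, with wide uncertainty. For compound 4 the estimated value is 9000 nM, with an expected range of 3500 nM to 25000 nM.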

Compound 4, half-maximal inhibitory concentration: 2950 nM
Compound 4: middle estimate off by 3.1-fold (0.48 log units), on the high side; measured number below the stated range.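

In this assay, the change on the amine nitrogen gives a 1.7-fold lower number from compound 1 to compound 4 (0.23 log units; within the scatter), so 4-propylphenyl and 2-methoxyphenyl are not told apart at this position. The entering group brings an oxygen and a hydrogen-bond acceptor, and with this exchange the series gains its first readable step between two aryl groups, one that stays within the scatter. Nothing measured here bears on a cause for this result.

On these data alone, compound 3, with 4-methoxyphenyl, stands at > 8000 nM, which is a limit, and the steps that involve a limit cannot be read, so how the two methoxyphenyl compounds compare stays open. Also open, as far as these compounds go, is how this assay would read with a carboxylic acid, a basic amine or a longer alkyl chain on the phenyl ring at this nitrogen.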